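3-Fluoropyridin-2-yl in place of 2H-1,2,3-triazol-2-yl

The compounds below may be only part of what the source reports. "The series", "measured", "known", "first", "only" and "open" are said of these compounds alone.

In an ADME assay on a cell-free system (plasma, Rattus norvegicus) for protein binding, compound 1 (`Cc1ccc(-c2cc(C(=O)N[C@H](C)c3nc(C)no3)cc(-c3ncccc3F)c2)nc1`) gives 99.6%, compound 2 (`Cc1ccc(-c2cc(C(=O)N[C@H](C)c3ccc(C(F)(F)F)nc3)cc(-c3ncccc3F)c2)nc1`) gives 98.6% and compound 3 (`Cc1ccc(-c2cc(C(=O)N[C@H](C)c3ccc(F)cn3)cc(-n3nccn3)c2)nc1`) gives 97.4%. Compound 3 lies within the scatter of compound 2 and has clearly more free compound than compound 1. Compound 4 (`Cc1ccc(-c2cc(C(=O)N[C@H](C)c3ccc(F)cn3)cc(-c3ncccc3F)c2)nc1`) carries 3-fluoropyridin-2-yl in place of 2H-1,2,3-triazol-2-yl on an aromatic carbon. Among the measured compounds shown here, no measured step makes this exchange. For the measured compounds named here, compounds 1 and 2 both carry the entering group, and the one bearing step, a 3.5-fold higher unbound fraction from compound 1 to compound 2 (0.54 log units; beyond the scatter), is modest and concerns another group. A step of similar size toward less free compound is therefore expected. The expected change is a 2.2-fold lower unbound fraction from compound 3 to compound 4 (0.34 log units; beyond the scatter). Compound 4 is estimated at 98.8%, with an expected range of 97.8% to 99.5%.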

Compound 4, plasma protein binding: 99.2%
Beside the measured number, compound 4's estimate is 1.5-fold (0.18 log units) (unbound fraction) above it, within the range that was stated.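

In this assay, among the compounds shown here, the exchange of 2H-1,2,3-triazol-2-yl for 3-fluoropyridin-2-yl on the aromatic carbon, read directly for the first time, gives a 3.3-fold lower unbound fraction from compound 3 to compound 4 (0.51 log units; beyond the scatter) and so lies beyond the scatter. With 3-fluoropyridin-2-yl in place, replacing the group on the saturated chain carbon with 5-fluoropyridin-2-yl gives a 1.8-fold lower unbound fraction from compound 2 to compound 4 (0.24 log units; within the scatter) and a 2.0-fold higher unbound fraction from compound 1 to compound 4 (0.30 log units; within the scatter) and both stay within the scatter. Nothing available gives a cause for the step at the aromatic carbon.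

On these data alone, it remains open whether the step at the aromatic carbon holds with the other groups on the saturated chain carbon. As far as these compounds go, how an amine or a carboxylic acid on that aromatic carbon would compare also remains open.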